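Working notes on compound 3 from compound 2

This account rests on a few compounds, and the source may have more. Where it says the series, first, only, none or still open, it means among the compounds named here.

Measured so far:
compound 1 `O=C(COc1cccc2ccccc12)N/N=C/c1cccc(Br)c1` gives 100 ug/mL in an ADME assay on HEL cells (Homo sapiens) for cytotoxicity; on this read-out higher numbers stand for lower toxicity in this test and lower numbers for higher toxicity in this test
compound 2 `O=C(COc1cccc2ccccc12)N/N=C/c1cccc(Cl)c1` gives 100 ug/mL in this assay

Compound 2 stands level with compound 1 on the numbers shown, the step being no change at the digits printed from compound 1 to compound 2 (within the scatter). Compound 3 `Cc1ccc(/C=N/NC(=O)COc2cccc3ccccc23)cc1` differs from compound 2 by 4-methylphenyl in place of 3-chlorophenyl on a carbon with a double bond to nitrogen. Among the compounds with values here, the only measured step, chloro for bromo, bears on it just in its part of the structure and gave no change at the digits printed from compound 1 to compound 2 (within the scatter); no measured step covers a methyl group entering. A step of no change at the digits printed from compound 2 to compound 3 (within the scatter) is therefore expected, none beyond the scatter. Compound 3 is estimated at 100 ug/mL, within 50 ug/mL to 200 ug/mL.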

Compound 3, minimum cytotoxic concentration in the HEL assay: 20 ug/mL
The estimate for compound 3 lay 5.0-fold (0.70 log units) above the measured number; the whole stated range lies above it.
By their numbers in the HEL assay, from the lowest: compound 3; then compounds 1 and 2 (each within the scatter of the next).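

In the HEL assay this position does respond: 4-methylphenyl in place of the halophenyl groups gives a 5.0-fold lower number from compound 2 to compound 3 (0.70 log units; beyond the scatter) and a 5.0-fold lower number from compound 1 to compound 3 (0.70 log units; beyond the scatter) while chloro for bromo gave no step beyond the scatter. In a physicochemical assay for lipophilicity, measured as octanol-water partition (a lower number here means a more polar compound, a higher number a more lipophilic compound), compound 2 gives 4.54 and compound 3 gives 4.49 within the scatter of each other, so the partition coefficient does not separate them. Nothing at hand gives a cause for the step.

Compound 3 changes both the substituent and its ring position, so these two changes cannot be told apart. On these data alone, a 4-chlorophenyl or 3-methylphenyl group would separate them, and an aminophenyl group at this place remains untested ground in the HEL assay for this series.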